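Second chloro on the phenyl ring of compound 2

The source may hold more compounds than are shown below. What is called first, only, known or untested is meant among the compounds shown, and "the series" means these compounds.

Measured compounds:
compound 1 `Cc1nc2cc(OC[C@H](O)CN3CCN(Cc4noc(-c5ccc(C(C)(C)C)cc5)n4)CC3)ccc2s1` — 180 nM
compound 2 `Cc1nc2cc(OC[C@H](O)CN3CCN(Cc4noc(-c5ccc(Cl)cc5)n4)CC3)ccc2s1` — 2270 nM
compound 3 `Cc1nc2cc(OC[C@H](O)CN3CCN(Cc4nc(-c5ccc(C(C)(C)C)cc5)no4)CC3)ccc2s1` — 570 nM

All three were tested in a functional assay on mitochondria from heart for inhibition of peroxisomal acyl-coenzyme A oxidase 1 (Rattus norvegicus); a lower number here means a stronger inhibitor, a higher number a weaker inhibitor. Among these numbers compound 2 stands highest: compound 3 sits below it, and compound 1 lies furthest below. Within the data shown here, the one measured change at the phenyl ring end of the molecule is a 13-fold higher number from compound 1 to compound 2 (1.10 log units; beyond the scatter), so the group on that ring clearly matters for this assay.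

Compound 4 `Cc1nc2cc(OC[C@H](O)CN3CCN(Cc4noc(-c5ccc(Cl)c(Cl)c5)n4)CC3)ccc2s1` differs from compound 2 by chloro in place of hydrogen on an aromatic carbon. Among the measured compounds shown here, no measured pair shows what a second chloro does here; the step from compound 1 to compound 2 only shows that a larger group on that ring went with a lower number. For the measured compounds named here, a second chloro adds one heavy atom to the ring, so a small move toward a lower number is expected, though the single measured step gives no firm footing, and a change within the scatter would not be surprising.

Compound 4 is therefore expected to give about 1100 nM in this assay, between 350 nM and 3500 nM, a step of a 2.1-fold lower number from compound 2 to compound 4 (0.31 log units; beyond the scatter).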

Compound 4, half-maximal inhibitory concentration: 550 nM
Compound 4: the middle estimate sits 2.0-fold (0.30 log units) above what was measured, within the range that was stated.
By their numbers in this assay, from the lowest: compound 1; then compounds 4 and 3 (each within the scatter of the next); then compound 2.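

Adding a chloro ortho to the chloro group already on the ring gives a 4.1-fold lower number from compound 2 to compound 4 (0.62 log units; beyond the scatter) in this assay and so shows that this position is not silent: one added chlorine atom moves the number, whereas the earlier step swapped one whole group for another. The 3,4-dichlorophenyl ring wins back only part of what was lost on going to the single chloro, since the step to it from the tert-butyl compound is still a 3.1-fold higher number from compound 1 to compound 4 (0.49 log units; beyond the scatter) and lies beyond the scatter. Nothing shown here explains why the number moves at this position.

As far as these compounds go, whether a methyl, a methoxy or a trifluoromethyl group at the same place would lower the number as chloro does stays open. So does whether the 3,4-dichlorophenyl ring would act the same way with the linking ring turned as in compound 3.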